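The source may report more compounds than this note shows. Statements on the series, on what has been measured and on what is new or still open speak of the compounds shown alone.

Three compounds share one core and differ only in what sits on the aromatic ring attached to the carbonyl. In a functional assay on MDA-MB-231 cells (Homo sapiens) for cytotoxicity, read by MTT assay, with a stated time of 48 h (a higher number here means a weaker inhibitor, a lower number a stronger inhibitor), compound 1 `O=C(/C=C/c1ccc2c(c1)B(O)OC2)c1ccccc1` gives 2300 nM, the lowest of the three numbers. Compound 2 `O=C(/C=C/c1ccc2c(c1)B(O)OC2)c1ccc(OCc2ccccc2)cc1` gives 5300 nM and compound 3 `O=C(/C=C/c1ccc2c(c1)B(O)OC2)c1ccc(O)cc1` gives 25600 nM. The steps away from compound 1 were a 2.3-fold higher number from compound 1 to compound 2 (0.36 log units; beyond the scatter) and an 11-fold higher number from compound 1 to compound 3 (1.05 log units; beyond the scatter); between the two substituted compounds there was a 4.8-fold higher number from compound 2 to compound 3 (0.68 log units; beyond the scatter). Compound 4 `O=C(/C=C/c1ccc2c(c1)B(O)OC2)c1ccc(C(F)(F)F)cc1` carries a further change: trifluoromethyl in place of hydrogen on an aromatic carbon. Both earlier steps that add a group at this place raised the number, one modestly and one largely, so a modest rise is expected here as well, a 1.5-fold higher number from compound 1 to compound 4 (0.18 log units; within the scatter). Compound 4 is therefore estimated at 3500 nM, within a range from 1500 nM to 9000 nM.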

Compound 4, half-maximal inhibitory concentration: 9200 nM
Beside the measured number, compound 4's estimate is 2.6-fold (0.42 log units) below it, and the stated range ends below it.
By their numbers in this assay, from the lowest: compound 1; then compounds 2 and 4 (each within the scatter of the next); then compound 3.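

Trifluoromethyl also raises the number in this assay, giving a 4.0-fold higher number from compound 1 to compound 4 (0.60 log units; beyond the scatter), so all three groups tried at this place give a higher number than hydrogen. Replacing hydroxy with trifluoromethyl gives a 2.8-fold lower number from compound 3 to compound 4 (0.44 log units; beyond the scatter), while replacing benzyloxy with it gives a 1.7-fold higher number from compound 2 to compound 4 (0.24 log units; within the scatter), a step that stays within the scatter. Nothing available explains these differences. On these data alone, whether an amine or a carboxylic acid here would stay close to compound 1 remains open. Also open, as far as these compounds go, is whether any group at this place can bring the number lower than hydrogen does.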